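The source may hold more compounds than are shown below. What is called first, only, known or untested is meant among the compounds shown, and "the series" means these compounds.

Measured so far:
compound 1 `CCn1cnc(Nc2nc(N[C@@H](C)c3ccc(F)cn3)nc3cccc(F)c23)c1` — in an assay on isolated protein for inhibition of G protein-coupled receptor kinase 6 (Homo sapiens), read by scintillation counting, radiometric assay and 33P incorporation, with a stated time of 80 min, in the presence of a further agent that is not named here (on this read-out higher numbers stand for weaker inhibition and lower numbers for stronger inhibition), compound 1 gives 280 nM
compound 2 `CCc1cc(Nc2nc(N[C@@H](C)c3cccc(F)c3)nc3ccccc23)n[nH]1` — in this assay compound 2 gives 340 nM

Compound 1 stands at the lowest of the two numbers, but its nearest neighbour, compound 2, lies within the usual scatter, so the two cannot be told apart on these data. Compound 3 `CCc1cc(Nc2nc(N[C@@H](C)c3ccc(F)cn3)nc3cccc(F)c23)n[nH]1` is built from compound 1 by one change: a group of 7 heavy atoms (5 carbon, 2 nitrogen; one five-membered aromatic ring with 2 hetero atoms) in place of a group of 7 heavy atoms (5 carbon, 2 nitrogen; one five-membered aromatic ring with 2 hetero atoms), on a nitrogen on an aromatic ring. The same 5-ethyl-1H-pyrazol-3-yl group already sits on compound 2, where it goes with a number close to that of compound 1, though compound 2 also differs elsewhere. Among the measured compounds shown here, no single-point step between measured compounds is available. The expectation is therefore a change no larger than the scatter, with a small lean toward a lower number, giving an expected step of a 1.2-fold lower number from compound 1 to compound 3 (0.09 log units; within the scatter). Compound 3 is estimated at 230 nM, with a likely range from 90 nM to 600 nM.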

Compound 3, half-maximal inhibitory concentration: 29 nM
Beside the measured number, compound 3's estimate is 7.9-fold (0.90 log units) above it; measured number below the stated range.
By their numbers in this assay, from the lowest: compound 3; then compounds 1 and 2 (each within the scatter of the next).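

The group on this nitrogen matters more than the two earlier compounds could show: in this assay, two groups with the same atoms and the same kind of ring, joined differently, give a 9.7-fold lower number from compound 1 to compound 3 (0.98 log units; beyond the scatter). At this position, then, the arrangement of the atoms counts and not merely their number, and the entering 5-ethyl-1H-pyrazol-3-yl carries a hydrogen-bond donor where the leaving group has none. No measurement here explains why this change has such an effect.

As far as these compounds go, it remains open whether the ethyl chain itself is needed, or whether a methyl group or a propyl chain on the same ring would give a similar number. Compound 2 differs from compound 3 in more than one place, so the part played by the rest of the molecule also stays unresolved.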